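Benzoyl replaces the carboxyethyl chain on the core nitrogen

The source may hold more compounds than are shown below. What is called first, only, known or untested is meant among the compounds shown, and "the series" means these compounds.

Measured so far in an ADME assay on L929 cells (Mus musculus) for cytotoxicity, read by resazurin assay, with a stated time of 48 h; on this read-out higher numbers stand for lower toxicity in this test and lower numbers for higher toxicity in this test:
compound 1 `O=C(O)CCn1c2ccc([N+](=O)[O-])cc2c(=O)n1Cc1ccccc1` gives > 256000 nM
compound 2 `CC(=O)OCCn1c2ccc([N+](=O)[O-])cc2c(=O)n1Cc1ccccc1` gives > 256000 nM
compound 3 `O=C(OCc1ccccc1)n1c2ccc([N+](=O)[O-])cc2c(=O)n1Cc1ccccc1` gives 86100 nM

Compound 1 stands at a limit of this assay rather than at a number, and the value given for compound 2 is a limit as well, so the limit of > 256000 nM in this assay, at which 2 of the 3 values shown sit, is where two of the three measured compounds sit. Only compound 3 gives a number inside the measured window.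

The new compound 4 `O=C(c1ccccc1)n1c2ccc([N+](=O)[O-])cc2c(=O)n1Cc1ccccc1` differs from compound 1 in one place: benzoyl in place of 2-carboxyethyl on an aromatic nitrogen. Going by the values given here, the step that bears on this change is the one to compound 3, where the measured record shows an at least 2.9-fold lower number from compound 1 to compound 3 (0.47 log units; beyond the scatter), and the parallel step an at least 2.9-fold lower number from compound 2 to compound 3 (0.47 log units; beyond the scatter). Both put an acyl-type group on the aromatic nitrogen in place of a saturated two-carbon chain, and both move the number at least modestly downward out of the limit. The benzoyl group in compound 4 is of the same kind, so a downward step of at least that size from compound 1 is expected, landing compound 4 near where compound 3 stands.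

For compound 4 the expected step is an at least 2.8-fold lower number from compound 1 to compound 4 (0.45 log units; beyond the scatter), and the estimate for compound 4 in this assay is 90000 nM, with a range from 35000 nM to 230000 nM.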

Compound 4, concentration lethal to 50% of the cells: 146000 nM
Compound 4: middle estimate off by 1.6-fold (0.21 log units), on the low side; low and high end bracket the measured number.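

In this assay, the result gives a second number inside the measured window for a group joined through a carbonyl to the aromatic nitrogen, and the change on that carbonyl carbon gives a 1.7-fold higher number from compound 3 to compound 4 (0.23 log units; within the scatter), so phenyl and benzyloxy cannot be told apart there. Across the four compounds, the two with a carbonyl group on this nitrogen, compound 3 and compound 4, give numbers, while the two with a saturated chain there, compound 1 and compound 2, stay at a limit, and none of the four goes against this. The benzoyl change itself can be read only as a floor, an at least 1.7-fold lower number from compound 1 to compound 4 (0.24 log units; that floor lies within the scatter) and an at least 1.7-fold lower number from compound 2 to compound 4 (0.24 log units; that floor lies within the scatter), because compound 1 and compound 2 are limits and not numbers: the limit of > 256000 nM in this assay, at which 2 of the 4 values shown sit.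

What a plain benzyl group or an acetyl group would give on the aromatic nitrogen stays open, so the compounds shown do not separate the carbonyl on that nitrogen from the aromatic ring that compound 3 and compound 4 both carry. Whether an amine or a urea carbonyl at this place would stay at the limit or give a number is open as well.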